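From pyridin-2-yl to pyridin-4-yl: a step without precedent

The source may hold more compounds than are shown below. What is called first, only, known or untested is meant among the compounds shown, and "the series" means these compounds.

Of the compounds shown here, three sharing one core have been tested in a functional assay on HT-29 cells (Homo sapiens) for antiproliferative activity (on this read-out higher numbers stand for weaker inhibition of growth and lower numbers for stronger inhibition of growth), and they differ only in a single group. Compound 1 `c1ccc(-c2cc(-c3ccsc3)cc(-c3ccccn3)n2)nc1`, with thiophen-3-yl, gives 0.0027 ug/mL. Compound 2 `c1ccc(-c2cc(-c3ccco3)cc(-c3ccccn3)n2)nc1`, with furan-2-yl, gives 0.0024 ug/mL. Compound 3 `c1ccc(-c2cc(-c3cccs3)cc(-c3ccccn3)n2)nc1`, with thiophen-2-yl, gives 0.0018 ug/mL. Exchanging this group hardly matters: a 1.1-fold lower number from compound 1 to compound 2 (0.05 log units; within the scatter), a 1.5-fold lower number from compound 1 to compound 3 (0.18 log units; within the scatter) and a 1.3-fold lower number from compound 2 to compound 3 (0.12 log units; within the scatter). Compound 3 therefore stands level with the other two.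

Compound 4 `c1ccc(-c2cc(-c3cccs3)cc(-c3ccncc3)n2)nc1` keeps thiophen-2-yl but changes elsewhere: pyridin-4-yl in place of pyridin-2-yl on an aromatic carbon. Pyridin-4-yl comes in place of pyridin-2-yl on an aromatic carbon next to the ring nitrogen, so the atoms stay the same and only their connection differs. For the measured compounds named here, none of the measured steps touches this place, so they offer no size for this change, and the data show nothing about pyridin-4-yl at all. With compound 3 at 0.0018 ug/mL, the number has more room to rise than to fall, so a move towards weaker inhibition of growth is expected, though with little certainty. The expected change is a 28-fold higher number from compound 3 to compound 4 (1.44 log units; beyond the scatter). Compound 4 is estimated at 0.05 ug/mL, with an expected range from 0.004 ug/mL to 1.5 ug/mL.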

Compound 4, concentration for 50% growth inhibition: 0.52 ug/mL
Estimate against measurement, compound 4: 10-fold (1.02 log units) below, and the stated range covers the measured number.
By their numbers in this assay, from the lowest: compounds 3, 2 and 1 (each within the scatter of the next); then compound 4.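

In this assay, replacing pyridin-2-yl with pyridin-4-yl gives a 290-fold higher number from compound 3 to compound 4 (2.46 log units; beyond the scatter), even though the two groups have the same atoms and differ only in how those atoms are joined. The exchanges among thiophen-3-yl, furan-2-yl and thiophen-2-yl stayed within the scatter, whereas this place, on an aromatic carbon next to the ring nitrogen of the shared core, proves highly sensitive to a change that leaves the counted features of the group untouched, so the connection of the pyridine ring matters here far more than the choice among those three rings did at the other place. No measurement shown here accounts for the size of this step.

The compounds shown leave open whether pyridin-2-yl is specifically required or pyridin-4-yl is specifically poor, a question that pyridin-3-yl or a plain phenyl ring at this place could help to settle. As far as these compounds go, it also remains open whether the same exchange would have a similar effect with thiophen-3-yl or furan-2-yl in place of thiophen-2-yl.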